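Replacing the 3-fluorophenyl on the Sulfonyl Sulfur

The compounds below may be only part of what the source reports. "The series", "measured", "known", "first", "only" and "open" are said of these compounds alone.

Compound 2 `CN1CCCC(n2cc(S(=O)(=O)c3cccc(F)c3)c3cccnc32)C1` gives the lower of the two numbers in a functional assay on HeLa cells for agonist activity at 5-hydroxytryptamine receptor 6 (Homo sapiens), read by cAMP accumulation and immunoassay (on this read-out lower numbers stand for smaller maximal responses and higher numbers for larger maximal responses), namely 75%; compound 1 `O=S(=O)(c1cccc(F)c1)c1cn(C2CCCNC2)c2ncccc12` gives 84%, and the step of a number 9 percentage points lower from compound 1 to compound 2 (within the scatter) lies within the scatter. Compound 3 `CN1CCCC(n2cc(S(=O)(=O)C3=C(Cl)NC4SC=CN34)c3cccnc32)C1` differs from compound 2 only on the sulfonyl sulfur: a group of 9 heavy atoms (5 carbon, 2 nitrogen, 1 sulfur, 1 chlorine; 2 five-membered non-aromatic rings with 2 hetero atoms each) in place of a group of 7 heavy atoms (6 carbon, 1 fluorine; one six-membered aromatic ring of carbon only), on a sulfonyl sulfur. No measured step touches that position, so nothing shown bears directly on this change, and a step within the scatter is expected, as a number 3 percentage points lower from compound 2 to compound 3 (within the scatter). Compound 3 is therefore estimated at 72%, with a range from 45% to 95%.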

Compound 3, largest response reached (Emax), in percent of the reference or control that the assay uses: 68%
Compound 3: middle estimate off by 4 percentage points, on the high side; the measured number falls inside the stated range.
By their numbers in this assay, from the lowest: compounds 3, 2 and 1 (each within the scatter of the next, the first and the last beyond it).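

In this assay, going by these compounds alone, the first exchange at this position, on a sulfonyl sulfur, gives a number 7 percentage points lower from compound 2 to compound 3 (within the scatter). The 3-fluorophenyl and the entering group therefore cannot be told apart here, although the entering group has no aromatic ring and carries a hydrogen-bond donor and hydrogen-bond acceptors that the 3-fluorophenyl lacks. No available evidence accounts for this result.

On these data alone, it remains open how a plain phenyl or a methyl on the sulfonyl sulfur would read. Also open, as far as these compounds go, is whether hydrogen in place of methyl on the ring amine nitrogen would matter alongside the entering group.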